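The compounds below may be only part of what the source reports. "The series", "measured", "known", "first", "only" and "open" are said of these compounds alone.

Measured compounds:
compound 1 `COc1ccc2c(OCC[C@@H]3NC(=O)N(C)CCCC/C=C\[C@@H]4C[C@@]4(C(=O)NS(=O)(=O)C4(C)CC4)NC3=O)cc(-n3ccc(C(C)C)n3)nc2c1Cl` — 31000 nM
compound 2 `COc1ccc2c(OCC[C@@H]3NC(=O)N(C)CCCC/C=C\[C@@H]4C[C@@]4(C(=O)NS(=O)(=O)C4(C)CC4)NC3=O)cc(-c3nc(C(C)C)cs3)nc2c1Br` — 28300 nM

In an ADME assay on cells (Homo sapiens) for activation (a higher number here means that more compound is tolerated, a lower number that less compound is tolerated), compound 2 gives 28300 nM, the lower of the two numbers, while compound 1 gives 31000 nM, a gap that lies within the scatter. Compound 3 `COc1ccc2c(OCC[C@@H]3NC(=O)N(C)CCCC/C=C\[C@@H]4C[C@@]4(C(=O)NS(=O)(=O)C4(C)CC4)NC3=O)cc(-c3nc(C(C)C)cs3)nc2c1F` is not yet measured. It differs from compound 2 by fluoro in place of bromo on an aromatic carbon. Going by the values given here, no step between measured compounds is known, so the account rests on the two values alone. The step from compound 2 to compound 3 is expected to be small, in either direction or none beyond the scatter, with a 1.1-fold higher number from compound 2 to compound 3 (0.03 log units; within the scatter) as the estimate. Compound 3 is expected to give 30000 nM in this assay, within a range of 15000 nM to 60000 nM.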

Compound 3, half-maximal cytotoxic concentration: 57100 nM
Beside the measured number, compound 3's estimate is 1.9-fold (0.28 log units) below it; measured number inside the range.
By their numbers in this assay, from the lowest: compounds 2, 1 and 3 (each within the scatter of the next).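

Going by these compounds alone, this is the first pair that differs in one place, and in this assay fluoro in place of bromo on this aromatic carbon, ortho to a methoxy group, gives a 2.0-fold higher number from compound 2 to compound 3 (0.30 log units; within the scatter). At this position, this exchange alone therefore does not move the number beyond the scatter. Nothing available explains this step.

The compounds shown leave open how a methyl, a trifluoromethyl or a nitrile on this same carbon would read. They also leave open whether this exchange would give a similar step on a core carrying a different group elsewhere.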